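From a 4-fluorophenyl to a (2-chlorophenyl)carbonyl group

The source may report more compounds than this note shows. Statements on the series, on what has been measured and on what is new or still open speak of the compounds shown alone.

Of the compounds shown here, three sharing one core have been tested in a functional assay on SGC-7901 cells (Homo sapiens) for antiproliferative activity, read by MTT assay, with a stated time of 24 h; on this read-out lower numbers stand for stronger inhibition and higher numbers for weaker inhibition. Compound 1 `Cc1ccccc1NNC(=O)c1ccccc1NS(=O)(=O)c1cnc(O)nc1O` gives > 20000 nM, which is a limit and not a number. Compound 2 `O=C(NNc1ccccc1Cl)c1ccccc1NS(=O)(=O)c1cnc(O)nc1O` gives > 20000 nM, again a limit. Compound 3 `O=C(NNc1ccc(F)cc1)c1ccccc1NS(=O)(=O)c1cnc(O)nc1O` gives > 20000 nM, also a limit. The series therefore offers no number to rank them by: the limit of > 20000 nM in this assay, at which 3 of the 3 values shown sit.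

Compound 4 `O=C(NNC(=O)c1ccccc1NS(=O)(=O)c1cnc(O)nc1O)c1ccccc1Cl` is still unmeasured. It carries (2-chlorophenyl)carbonyl in place of 4-fluorophenyl on an amine nitrogen. The measured steps that bear on this change are a step that the two limits leave unreadable from compound 1 to compound 3 and a step that the two limits leave unreadable from compound 2 to compound 3, together with a step that the two limits leave unreadable from compound 1 to compound 2. None of them has a readable size, and none of them introduces the new carbonyl, so the forecast is weakly grounded.

No clear change in either direction is expected, so the estimated step that the limit leaves unreadable from compound 3 to compound 4 is no larger than the scatter. For compound 4 the expected value is 25000 nM, with an estimated range from 9000 nM to 60000 nM.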

Compound 4, half-maximal inhibitory concentration: 2410 nM
Compound 4: the middle estimate sits 10-fold (1.02 log units) above what was measured, and the stated range ends above it.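

Placing a carbonyl on this amine nitrogen gives the series its first readable result in this assay: an at least 8.2-fold lower number from compound 3 to compound 4 (0.91 log units; beyond the scatter), an at least 8.2-fold lower number from compound 1 to compound 4 (0.91 log units; beyond the scatter) and an at least 8.2-fold lower number from compound 2 to compound 4 (0.91 log units; beyond the scatter). The last of these steps is the closest comparison, as the 2-chlorophenyl ring is present on both sides and the carbonyl is what enters, and all three sizes are only minimum sizes. The steps among the earlier compounds cannot be read, and compound 4 is the only compound shown with a number instead of a limit: the limit of > 20000 nM in this assay, at which 3 of the 4 values shown sit.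

The compounds shown leave open whether the carbonyl is enough by itself or works only with the chlorine on its ring, which a plain phenylcarbonyl group would test. They also leave open whether any ring is needed at this place, which an acetyl group would test.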